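A few compounds are considered here, and "the series" means these few. Any claim that something is new, unique, unknown or untested is made for them only; others in the source may bear on it.

In a functional assay on HeLa cells (Homo sapiens) for cytotoxicity, read by MTT assay, with a stated time of 48 h (on this read-out lower numbers stand for stronger inhibition and higher numbers for weaker inhibition), compound 1 `O=c1ccoc2cc(OCc3cn(Cc4ccccc4Br)nn3)ccc12` gives 14500 nM. In this assay compound 2 `CC(C)(C)c1ccc(Cn2cc(COc3ccc4c(=O)ccoc4c3)nn2)cc1` gives 17600 nM; the two numbers lie within the usual scatter of each other, so on these data the two compounds cannot be told apart. Compound 3 `O=c1ccoc2cc(OCc3cn(Cc4ccc(Cl)cc4)nn3)ccc12` has not yet been measured. It differs from compound 1 in one place: 4-chlorophenyl in place of 2-bromophenyl on a saturated chain carbon bound to an aromatic nitrogen. No measured step of this kind exists among the compounds shown, so the change expected from compound 1 to compound 3 is a 1.0-fold higher number from compound 1 to compound 3 (0.01 log units; within the scatter), none beyond the scatter. Compound 3 is therefore estimated at 15000 nM, with a range from 7000 nM to 32000 nM.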

Compound 3, half-maximal inhibitory concentration: 37600 nM
Compound 3: the middle estimate sits 2.5-fold (0.40 log units) below what was measured, and the stated range ends below it.
By their numbers in this assay, from the lowest: compounds 1 and 2 (each within the scatter of the next); then compound 3.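

The group on this saturated chain carbon does move the number in this assay, which compound 1 and compound 2 alone did not show: 4-chlorophenyl in place of 2-bromophenyl gives a 2.6-fold higher number from compound 1 to compound 3 (0.41 log units; beyond the scatter) in this series, and chloro in place of tert-butyl on an aromatic carbon gives a 2.1-fold higher number from compound 2 to compound 3 (0.33 log units; beyond the scatter) as a second modest step. Nothing shown here explains either step.

The first step changes both the halogen and its ring position, so these remain unseparated. As far as these compounds go, how 4-bromophenyl would compare stays open, as does the effect of an amine or a carboxylic acid on that ring.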